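The source may hold more compounds than are shown below. What is called first, only, known or untested is meant among the compounds shown, and "the series" means these compounds.

Going by the values given here, compound 1 `O=C(Nc1ccccc1)Nc1cccc(CNc2nccnc2Cl)c1` sits at the top of the three numbers so far in a functional assay on MGC-803 cells (Homo sapiens) for antiproliferative activity, read by MTT assay, with a stated time of 48 h (a higher number here means a weaker inhibitor, a lower number a stronger inhibitor), giving 16300 nM, though both of its neighbours lie within the usual scatter: compound 3 `Cc1ccccc1NC(=O)Nc1cccc(CNc2nccnc2Cl)c1` gives 14000 nM and compound 2 `CN(C)c1ccc(NC(=O)Nc2cccc(CNc3nccnc3Cl)c2)cc1` gives 11500 nM. The steps among them, a 1.2-fold lower number from compound 1 to compound 3 (0.07 log units; within the scatter), a 1.4-fold lower number from compound 1 to compound 2 (0.15 log units; within the scatter) and a 1.2-fold higher number from compound 2 to compound 3 (0.09 log units; within the scatter), all fall inside the scatter, so the series has not yet moved on this read-out.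

Compound 4 `O=C(Nc1cccc(CNc2nccnc2Cl)c1)NC1CCCCC1` differs from compound 1 by cyclohexyl in place of phenyl on an amide-type nitrogen. Among the compounds with values here, none of the measured steps touches this change: each of them only adds a substituent to the phenyl that is now replaced, and each stayed within scatter. There is therefore no basis for expecting a step beyond the scatter in this assay in either direction, and the estimate for compound 4 is kept near compound 1 with a wide range: compound 4 is expected to give 18000 nM, between 7000 nM and 45000 nM, which is an expected step of a 1.1-fold higher number from compound 1 to compound 4 (0.04 log units; within the scatter).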

Compound 4, half-maximal inhibitory concentration: > 40000 nM
Compound 4: no number, only a limit; the forecaster's own chance of this, stated with the estimate: 10%; at least 2.2-fold (0.34 log units) between middle value and limit.
By their numbers in this assay, from the lowest: compounds 2, 3 and 1 (each within the scatter of the next). At a limit, above all of these: compound 4.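

In this assay compound 4 gives only a limit, > 40000 nM, and not a number. Even so, the change from an aromatic to a non-aromatic ring on the amide-type nitrogen is the first to pass the scatter, with an at least 2.4-fold higher number from compound 1 to compound 4 (0.38 log units; beyond the scatter), an at least 2.8-fold higher number from compound 3 to compound 4 (0.45 log units; beyond the scatter) and an at least 3.4-fold higher number from compound 2 to compound 4 (0.54 log units; beyond the scatter), whereas the step between the two aryl groups of compound 2 and compound 3 stayed within it. Phenyl and cyclohexyl have the same heavy-atom count and the same hydrogen-bond counts, so at this position the counted difference lies in the aromatic ring alone.

From the compounds shown here alone, how far compound 4 lies past its limit remains open, so the true size of these steps cannot be read. Also open, going by these compounds, is whether a benzyl group, a cyclopentyl ring or a butyl chain on this nitrogen would stay with compounds 1 to 3 or follow compound 4.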